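Hydroxy for Hydrogen on the Shared Core

The source may hold more compounds than are shown below. What is called first, only, known or untested is meant among the compounds shown, and "the series" means these compounds.

Compound 3 `O=c1cc(-n2cc(COc3ccc(F)cc3)nn2)c2ccccc2o1` stands as the weaker of the two numbered compounds in a functional assay on MCF7 cells (Homo sapiens) for antiproliferative activity, read by MTT assay, with a stated time of 48 h (on this read-out higher numbers stand for weaker inhibition and lower numbers for stronger inhibition), where compound 3 gives 5840 nM. Compound 1 `O=c1cc(-n2cc(COc3ccccc3)nn2)c2cc(Br)ccc2o1` gives 1720 nM, a clearly lower number than compound 3. In this assay compound 2 `O=c1cc(-n2cc(COc3ccccc3)nn2)c2cc(O)ccc2o1` reaches only the limit of > 50000 nM. The change from compound 3 to compound 4 `O=c1cc(-n2cc(COc3ccc(F)cc3)nn2)c2cc(O)ccc2o1` is hydroxy in place of hydrogen on an aromatic carbon. Among the compounds with values here, the one measured step that bears on it is an at least 29-fold higher number from compound 1 to compound 2 (1.46 log units; beyond the scatter), at the same place on the shared core, which ended at the limit (the limit of > 50000 nM in this assay, at which 1 of the 3 values shown sits). A hydroxy group entering here is therefore expected to raise the number by a large step, a 12-fold higher number from compound 3 to compound 4 (1.08 log units; beyond the scatter), and a limit may again be all that is reported. Compound 4 is estimated at 70000 nM, within a range from 15000 nM to 300000 nM.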

Compound 4, half-maximal inhibitory concentration: 4620 nM
Compound 4: middle estimate off by 15-fold (1.18 log units), on the high side, and the stated range ends above it.
By their numbers in this assay, from the lowest: compound 1; then compounds 4 and 3 (each within the scatter of the next). At a limit, above all of these: compound 2.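

In this assay, hydroxy in place of hydrogen on the shared core leaves the result unchanged within the scatter: a 1.3-fold lower number from compound 3 to compound 4 (0.10 log units; within the scatter). With hydroxy already in place, fluoro in place of hydrogen on the other aromatic ring makes a large difference: an at least 10-fold lower number from compound 2 to compound 4 (1.03 log units; beyond the scatter). This step rests on a limit, as compound 2 gives only > 50000 nM, so hydroxy at this place does not by itself give a compound as weak as compound 2.

From the compounds shown here alone, whether fluoro has a similar effect with bromo on the core remains open. So does how an amine or a methoxy group would compare with hydroxy at this place.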